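Benzyl and phenoxy groups on a shared core

The compounds below may be only part of what the source reports. "The series", "measured", "known", "first", "only" and "open" are said of these compounds alone.

In a physicochemical assay for acid dissociation, compound 1 `COc1cccc(CNCCCNc2ccnc3cc(Cc4ccc(F)cc4)ccc23)c1O` gives 9.47 and compound 2 `COc1cccc(CNCCCNc2ccnc3cc(Cc4ccc(C#N)cc4)ccc23)c1O` gives 9.47 on the same core, with no change at the digits printed from compound 1 to compound 2 (within the scatter) between them. Compound 3 `COc1ccccc1Oc1ccc2c(NCCCNCc3cccc(OC)c3O)ccnc2c1` gives 9.28 and stands within the scatter of both others. Two measured steps place it, a number 0.19 log units lower from compound 1 to compound 3 (within the scatter) and a number 0.19 log units lower from compound 2 to compound 3 (within the scatter) as the readings show. In compound 4 `COc1cccc(CNCCCNc2ccnc3cc(Cc4ccc(F)cc4Cl)ccc23)c1O` the difference from compound 3 is 2-chloro-4-fluorobenzyl in place of 2-methoxyphenoxy on an aromatic carbon and amounts to 2-chloro-4-fluorobenzyl in place of 2-methoxyphenoxy on an aromatic carbon. The two steps that exchange 2-methoxyphenoxy for a substituted benzyl group at this place bear most directly on it, and both stayed within the scatter. For the measured compounds named here, no measured step isolates the added chloro substituent, so the expectation carries that gap. Nothing beyond the scatter is expected, and the estimated move is a number 0.17 log units higher from compound 3 to compound 4 (within the scatter) in this series. Compound 4 is expected at 9.45 with an estimated range from 9.2 to 9.7 in this assay when measured.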

Compound 4, acid dissociation constant: 9.47
Compound 4: middle estimate off by 0.02 log units, on the low side; low and high end bracket the measured number.
By their numbers in this assay, from the lowest: compounds 3, 1, 2 and 4 (each within the scatter of the next).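

In this assay, for the compounds shown here, the chloro substituent, which no earlier step isolated, can now be read alone: chloro in place of hydrogen on an aromatic carbon gives no change at the digits printed from compound 1 to compound 4 (within the scatter) on the shared core. The exchange of 4-cyanophenyl for 2-chloro-4-fluorophenyl gives no change at the digits printed from compound 2 to compound 4 (within the scatter) and the exchange of 2-methoxyphenoxy for 2-chloro-4-fluorobenzyl gives a number 0.19 log units higher from compound 3 to compound 4 (within the scatter), so none of the changes at this position leaves the scatter of the read-out. No measurement is at hand that could account for this.

As far as these compounds go, whether a group of another kind at this position, such as an amine or a carboxylic acid, would move the number beyond the scatter remains open. The compounds shown also leave open what a longer chain in place of the one they share would do.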